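This account rests on a few compounds, and the source may have more. Where it says the series, first, only, none or still open, it means among the compounds named here.

Working notes on the series.

Among the measured compounds shown here, compound 1 `O=c1[nH]cnc2c1c(-c1ccoc1)cn2[C@@H]1O[C@H](CO)[C@@H](O)[C@H]1O` sits at the weak end of the numbers so far: in a functional assay on K562 cells (Homo sapiens), read by MTT assay, with a stated time of 72 h (a higher number here means a weaker inhibitor, a lower number a stronger inhibitor), compound 1 gives 14500 nM, the highest of the three values. Compound 3 `Nc1nc2c(c(-c3ccoc3)cn2[C@@H]2O[C@H](CO)[C@@H](O)[C@H]2O)c(=O)[nH]1` differs from it by amino in place of hydrogen on an aromatic carbon; in this assay compound 3 gives 12500 nM, and the step of a 1.2-fold lower number from compound 1 to compound 3 (0.06 log units; within the scatter) stays within the scatter. For the measured compounds named here, compound 2 `Cc1nc(N)c2c(I)cn([C@@H]3O[C@H](CO)[C@@H](O)[C@H]3O)c2n1` differs from compound 1 in several places at once; in this assay compound 2 gives 1110 nM, and the two values alone show only that compound 2 is the stronger inhibitor of the pair.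

Compound 4 `O=c1[nH]cnc2c1c(-c1cc3ccccc3o1)cn2[C@@H]1O[C@H](CO)[C@@H](O)[C@H]1O` is the next member to be measured. It differs from compound 1 as follows: 1-benzofuran-2-yl in place of furan-3-yl on an aromatic carbon. Going by the values given here, no measured step touches this position or this exchange; the single step in hand, from compound 1 to compound 3, concerns a different carbon and was within the scatter. With nothing bearing on the exchange, the expected step of a 1.5-fold lower number from compound 1 to compound 4 (0.16 log units; within the scatter) is no more than the scatter itself, in no firm direction. Compound 4 is therefore estimated at 10000 nM, with a range of 3000 nM to 35000 nM.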

Compound 4, half-maximal inhibitory concentration: > 20000 nM
Compound 4 ended at the assay's limit; the forecaster's own chance of this, stated with the estimate: 10%; middle value at least 2.0-fold (0.30 log units) from the limit.
By their numbers in this assay, from the lowest: compound 2; then compounds 3 and 1 (each within the scatter of the next). At a limit, above all of these: compound 4.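

In this assay compound 4 gives > 20000 nM, which is a limit of the assay and not a number. Taken as a floor, the exchange of furan-3-yl for 1-benzofuran-2-yl on this aromatic carbon gives an at least 1.3-fold higher number from compound 1 to compound 4 (0.13 log units; that floor lies within the scatter), so the added six-membered aromatic ring brings no gain in strength, while the true size of the step stays unknown. This is the first reading at this carbon, and it is the only one that ends at the limit: the limit of > 20000 nM in this assay, at which 1 of the 4 values shown sits.

The compounds shown leave open how a phenyl ring, an aminomethyl group or a carboxylic acid would read on this carbon. Also open, from the compounds shown here alone, is whether 1-benzofuran-2-yl would read the same on the core of compound 3, which carries the amino group.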